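Replacing a ring at the edge of measurement

The compounds below may be only part of what the source reports. "The series", "measured", "known", "first", "only" and "open" are said of these compounds alone.

Of the compounds shown here, three sharing one core have been tested in a functional assay on A549 cells (Homo sapiens) for antiproliferative activity, read by spectrophotometry, with a stated time of 2 days; a lower number here means a stronger inhibitor of growth, a higher number a weaker inhibitor of growth. Among the measured compounds shown here, compound 1 `COc1cc(Nc2ncc(C(F)(F)F)c(N3Cc4cccc(N(C)S(C)(=O)=O)c4C3)n2)c(OC)cc1Cl` gives 7300 nM, the only measured number so far. Compound 2 `CN(c1cccc2c1CN(c1nc(Nc3ccc(C(F)(F)F)cc3)ncc1C(F)(F)F)C2)S(C)(=O)=O` reads > 30000 nM, which is a limit of the assay and not a number. Compound 3 `Cc1cc(C)cc(Nc2ncc(C(F)(F)F)c(N3Cc4cccc(N(C)S(C)(=O)=O)c4C3)n2)c1` reads > 30000 nM, which is also a limit. Compound 3 therefore offers no exact starting point, and it sits at the limit of > 30000 nM in this assay, at which 2 of the 3 values shown sit.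

The next compound, compound 4 `CN(c1cccc2c1CN(c1nc(Nc3cc(Cl)cc(C(F)(F)F)c3)ncc1C(F)(F)F)C2)S(C)(=O)=O`, changes only the group on the nitrogen: 3-chloro-5-(trifluoromethyl)phenyl in place of 3,5-dimethylphenyl on a nitrogen on an aromatic ring.

Changes at this same place have been measured. Leaving the 4-chloro-2,5-dimethoxyphenyl group of compound 1 gave an at least 4.1-fold higher number from compound 1 to compound 2 (0.61 log units; beyond the scatter), and likewise an at least 4.1-fold higher number from compound 1 to compound 3 (0.61 log units; beyond the scatter). Between the two weak compounds there is a step that the two limits leave unreadable from compound 2 to compound 3. The entering group carries a chlorine, as compound 1 does, and a trifluoromethyl, as compound 2 does, but it has no methoxy groups. Both departures from the group of compound 1 lost growth inhibition, so little recovery is expected in this assay. The expected change is an at least 1.2-fold lower number from compound 3 to compound 4 (0.07 log units; that floor lies within the scatter), which means no clear gain is anticipated. For compound 4 the estimate is 25000 nM, with an expected range of 9000 nM to 60000 nM.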

Compound 4, concentration for 50% growth inhibition: 6700 nM
For compound 4 the middle estimate is 3.7-fold (0.57 log units) above the measured one; measured number outside the range, below it.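

In this assay, growth inhibition at this place does not depend on the methoxy groups of compound 1: a group with no methoxy gives a 1.1-fold lower number from compound 1 to compound 4 (0.04 log units; within the scatter), so the two groups cannot be told apart here. The earlier losses therefore belong to the particular groups in compound 2 and compound 3 and not to every departure from the group of compound 1, as the 3-chloro-5-(trifluoromethyl)phenyl group gives an at least 4.4-fold lower number from compound 3 to compound 4 (0.65 log units; beyond the scatter) and an at least 4.4-fold lower number from compound 2 to compound 4 (0.65 log units; beyond the scatter). Compound 2 and compound 3 each stand at a limit and not a number, so these two steps give only minimum sizes: the limit of > 30000 nM in this assay, at which 2 of the 4 values shown sit.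

The step between compound 2 and compound 3 still cannot be read, and the compounds shown do not separate what the chlorine and the trifluoromethyl each contribute within the entering group. Going by these compounds, how a 3-chlorophenyl group, a 3-(trifluoromethyl)phenyl group or a nitrile in place of the chlorine would read remains open.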